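A Further Aryl Swap at an Unchanged Level

The compounds below may be only part of what the source reports. "The series", "measured", "known", "first", "only" and "open" are said of these compounds alone.

In a functional assay on DU-145 cells (Homo sapiens) for inhibition, read by trypan blue exclusion, with a stated time of 96 h (a lower number here means a stronger inhibitor of growth, a higher number a weaker inhibitor of growth), compound 1 `Cc1ccsc1/C=C(/SCc1ccc(Cl)cc1Cl)C(=O)c1ccc(Cl)cc1` gives 10000 nM. Among the compounds with values here, compound 2 `O=C(/C(=C\c1c[nH]c2ccc(Br)cc12)SCc1ccc(Cl)cc1Cl)c1ccc(Cl)cc1` gives 10000 nM, which places it level with compound 1, its only measured neighbour. The two differ in one place, with 5-bromo-1H-indol-3-yl in place of 3-methylthiophen-2-yl on a double-bonded chain carbon bound to a double-bonded chain carbon, and that exchange amounts to no change at the digits printed from compound 1 to compound 2 (within the scatter).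

Compound 3 `CN(C)c1ccc(/C=C(/SCc2ccc(Cl)cc2Cl)C(=O)c2ccc(Cl)cc2)cc1` keeps the shared core and alters the same place again: 4-(dimethylamino)phenyl in place of 5-bromo-1H-indol-3-yl on a double-bonded chain carbon bound to a double-bonded chain carbon. Here 4-(dimethylamino)phenyl enters in place of 5-bromo-1H-indol-3-yl. Within the data shown here, no measured compound carries this group, so the evidence is thin. Among the measured compounds shown here, with no change at the digits printed from compound 1 to compound 2 (within the scatter) as the only measured step at this place, no step beyond the scatter is expected in this assay. The expected size is a 1.3-fold lower number from compound 2 to compound 3 (0.10 log units; within the scatter). Compound 3 is estimated at 8000 nM, with an expected range of 3000 nM to 15000 nM.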

Compound 3, concentration for 50% growth inhibition: 50000 nM
Estimate against measurement, compound 3: 6.3-fold (0.80 log units) below; measured number above the stated range.
By their numbers in this assay, from the lowest: compounds 1 and 2 (each within the scatter of the next); then compound 3.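

In this assay, within the data shown here, this place on a double-bonded chain carbon bound to a double-bonded chain carbon proves sensitive to the group it carries: 4-(dimethylamino)phenyl in place of 5-bromo-1H-indol-3-yl gives a 5.0-fold higher number from compound 2 to compound 3 (0.70 log units; beyond the scatter), the first step here that lies beyond the scatter. The same group in place of 3-methylthiophen-2-yl gives a 5.0-fold higher number from compound 1 to compound 3 (0.70 log units; beyond the scatter), so the entering group stands apart from both earlier groups, which themselves showed no difference at the digits printed. Nothing measured on these compounds speaks to what lies behind this rise.

The compounds shown leave open whether the higher number goes with the dimethylamino group itself or with the phenyl ring that carries it, a question on which an unsubstituted phenyl ring or a primary amine in place of the dimethylamino group would bear. They also leave open whether any group at this place can bring the number below the level shared by compound 1 and compound 2, since the only departure from that level seen so far is upward.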